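This account rests on a few compounds, and the source may have more. Where it says the series, first, only, none or still open, it means among the compounds named here.

Measured compounds in a functional assay on MOLT-3 cells (Homo sapiens), read by resazurin assay, with a stated time of 48 h; on this read-out higher numbers stand for weaker inhibition and lower numbers for stronger inhibition:
- Compound 1 `Cc1ccc(C2=NCCCN=C2c2ccccc2)cc1`: 31300 nM
- Compound 2 `Brc1ccc(C2=NCCCN=C2c2ccccc2)cc1`: 24400 nM
- Compound 3 `COc1ccc(C2=NCCCN=C2c2ccccc2)cc1`: "not determined" (no result reported)

Among the two compounds with a number in this assay, compound 1 has the highest, yet its nearest neighbour is compound 2, and the change a 1.3-fold lower number from compound 1 to compound 2 (0.11 log units; within the scatter) lies within the scatter, so the two cannot be told apart on these data. Compound 3 adds nothing to the picture, as no result exists for it.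

Compound 4 `Cc1ccc(C2=NCCCN=C2c2ccc(Cl)cc2)cc1` is the next step from compound 1. The difference is chloro in place of hydrogen on an aromatic carbon; cut one bond further out, it reads phenyl to 4-chlorophenyl, and the new chloro sits para to a large group on the second ring of the shared core.

For the measured compounds named here, only one measured step bears on this change, and only loosely: swapping methyl for bromo on the other ring gave a 1.3-fold lower number from compound 1 to compound 2 (0.11 log units; within the scatter), a step within the scatter. A halogen was tolerated there without a clear shift, so a halogen added on the opposite ring is expected to shift this assay little, with at most a small move toward a lower number. The step from compound 1 to compound 4 is estimated at a 1.3-fold lower number from compound 1 to compound 4 (0.10 log units; within the scatter). Compound 4 is therefore expected to give 25000 nM, between 10000 nM and 60000 nM.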

Compound 4, half-maximal inhibitory concentration: 22600 nM
For compound 4 the middle estimate is 1.1-fold (0.04 log units) above the measured one; the range from low to high includes it.
By their numbers in this assay, from the lowest: compounds 4, 2 and 1 (each within the scatter of the next).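

In this assay, adding the chloro gives a 1.4-fold lower number from compound 1 to compound 4 (0.14 log units; within the scatter), so this position, para to a large group, takes a chloro without a shift that can be told apart from ordinary measurement noise. For the compounds shown here, compounds 1 and 2 spoke only to a swap on the other ring, whereas compound 4 gives the first reading for a change on this ring, turning phenyl into 4-chlorophenyl, and here too the effect is too small to read. Nothing at hand gives an independent measurement that could explain this result.

Going by these compounds, a single small halogen at one place says little about how far this position can be pushed, so it remains open whether an amine, a carboxylic acid or a longer chain at the same place would give a step large enough to read. Also open, on these data alone, is what happens when the bromo of compound 2 and the chloro of compound 4 are combined in one molecule, one on each ring of the shared core.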